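The compounds below may be only part of what the source reports. "The series", "measured", "known", "first", "only" and "open" are said of these compounds alone.

Compound 1 `c1ccc(-c2nc(-c3ccc4nc[nH]c4c3)no2)cc1` gives 12300 nM in a physicochemical assay for solubility, using potentiometric titration; a higher number here means a more soluble compound, a lower number a less soluble compound.
Compound 2 `FC(F)(F)c1ccccc1-c1nc(-c2ccc3nc[nH]c3c2)no1` gives 14000 nM in this assay.
Compound 3 `Clc1ccc(-c2nc(-c3ccc4nc[nH]c4c3)no2)cc1` gives 49500 nM in this assay.

Compound 3 stands highest of the three, beyond the scatter from both others. Compound 4 `OCCCCCc1ccc(-c2nc(-c3ccc4nc[nH]c4c3)no2)cc1` differs from compound 3 in one place: 5-hydroxypentyl in place of chloro on an aromatic carbon. Going by the values given here, two measured steps touch the same aromatic carbon: a 1.1-fold higher number from compound 1 to compound 2 (0.06 log units; within the scatter) and a 4.0-fold higher number from compound 1 to compound 3 (0.60 log units; beyond the scatter). Among the compounds with values here, neither exchanges chloro for 5-hydroxypentyl, so they show only that a change at this carbon can move this assay modestly or leave it within the scatter. The step to compound 4 is therefore expected to be a 1.4-fold lower number from compound 3 to compound 4 (0.15 log units; within the scatter), with little confidence in its direction. Compound 4 is estimated at 35000 nM, within a wide range from 9000 nM to 140000 nM.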

Compound 4, solubility: 37500 nM
Compound 4: the middle estimate sits 1.1-fold (0.03 log units) below what was measured; the measured number falls inside the stated range.
By their numbers in this assay, from the lowest: compounds 1 and 2 (each within the scatter of the next); then compounds 4 and 3 (each within the scatter of the next).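

At this aromatic carbon, the 5-hydroxypentyl chain and chloro are not told apart by this assay (a 1.3-fold lower number from compound 3 to compound 4 (0.12 log units; within the scatter)), although they differ greatly in size. Measured against hydrogen, the chain also stands beyond the scatter (a 3.0-fold higher number from compound 1 to compound 4 (0.48 log units; beyond the scatter)), so two quite different groups here both give a higher number than hydrogen. No available evidence explains this result. Left open is whether a plain pentyl chain, a longer chain or an amine at this carbon would give a similar number, and so whether the chain's hydroxyl end matters here.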